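The compounds below may be only part of what the source reports. "The series", "measured", "known", "first", "only" and "open" are said of these compounds alone.

Measured so far in this study:
compound 1 `CCOC(=O)/C=C1/SC(N2N=C(c3cc4ccccc4o3)CC2c2ccc(OC)c(OC)c2)=NC1=O`: 3.42 ug/mL
compound 2 `COC(=O)/C=C1/SC(N2N=C(c3cc4ccccc4o3)CC2c2ccc(F)cc2)=NC1=O`: 0.808 ug/mL
compound 3 `COC(=O)/C=C1/SC(N2N=C(c3cc4ccccc4o3)CC2c2ccc(Cl)cc2)=NC1=O`: 1.08 ug/mL

In a functional assay on A549 cells (Homo sapiens) for antiproliferative activity, read by MTT assay, with a stated time of 96 h (on this read-out lower numbers stand for stronger inhibition and higher numbers for weaker inhibition), compound 3 gives 1.08 ug/mL, the second highest of the three numbers. For the measured compounds named here, its nearest neighbour is compound 2, and the only single-point step among the measured compounds, a 1.3-fold higher number from compound 2 to compound 3 (0.13 log units; within the scatter), lies within the scatter. Compound 1 sits furthest away, with a number beyond the scatter from compound 3.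

Compound 4 `COC(=O)/C=C1/SC(N2N=C(c3cc4ccccc4o3)CC2c2ccc(OC)c(OC)c2)=NC1=O` has not yet been measured. It differs from compound 3 by 3,4-dimethoxyphenyl in place of 4-chlorophenyl on a saturated ring carbon. Going by the values given here, no measured step makes this exchange, so the one step seen bears on it only by showing that swapping one halogen for another at that ring carbon changed little. Compound 1 carries the same 3,4-dimethoxyphenyl group but differs from compound 4 elsewhere in the structure, so its value is only a hint: compound 1 gives 3.42 ug/mL, the highest of the three. On that hint compound 4 is expected to give a somewhat higher number than compound 3, a 2.3-fold higher number from compound 3 to compound 4 (0.36 log units; beyond the scatter), estimated at 2.5 ug/mL with a range from 1 ug/mL to 6 ug/mL.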

Compound 4, half-maximal inhibitory concentration: 0.967 ug/mL
Compound 4: middle estimate off by 2.6-fold (0.41 log units), on the high side; the measured number lies below the stated range.
By their numbers in this assay, from the lowest: compounds 2, 4 and 3 (each within the scatter of the next); then compound 1.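

At the saturated ring carbon, the aryl group can change with little effect in this assay: 3,4-dimethoxyphenyl replaces 4-chlorophenyl (a 1.1-fold lower number from compound 3 to compound 4 (0.05 log units; within the scatter)) and 4-fluorophenyl (a 1.2-fold higher number from compound 2 to compound 4 (0.08 log units; within the scatter)), and both steps lie within the scatter. Among these compounds, then, the entering group, with 10 heavy atoms and 2 hydrogen-bond acceptors, reads the same as the two halogen-bearing phenyl groups. For the compounds shown here, the one step beyond the scatter lies at the ester instead, where hydrogen replaces methyl on the saturated chain carbon bound to an oxygen next to a carbonyl group (a 3.5-fold lower number from compound 1 to compound 4 (0.55 log units; beyond the scatter)).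

From the compounds shown here alone, this ester step rests on a single pair, so it remains open whether it would hold with 4-fluorophenyl or 4-chlorophenyl, or how a longer chain or a carboxylic acid would read at that place. Nothing available explains why either position behaves as it does.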